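From carbamoyl to methanesulfonamido

A few compounds are considered here, and "the series" means these few. Any claim that something is new, unique, unknown or untested is made for them only; others in the source may bear on it.

Compound 1 `CN(C)c1ccc(O)c2ccccc12`: 18000 nM
Compound 2 `CCC(=O)Nc1ccc(O)c2ccccc12`: 16000 nM
Compound 3 `NC(=O)c1ccc(O)c2ccccc12`: 430000 nM

These values come from a functional assay, with a stated time of 15 min (a lower number here means that less compound is needed, a higher number that more compound is needed for the effect), where compound 3 has the highest number of the three, at 430000 nM. Compound 4 `CS(=O)(=O)Nc1ccc(O)c2ccccc12` remains unmeasured. It carries methanesulfonamido in place of carbamoyl on an aromatic carbon, para to a hydroxy group (methanesulfonamido in place of carbamoyl on an aromatic carbon).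

Going by the values given here, three measured steps bear on this change. Introducing carbamoyl gave two large steps: a 24-fold higher number from compound 1 to compound 3 (1.38 log units; beyond the scatter) and a 27-fold higher number from compound 2 to compound 3 (1.43 log units; beyond the scatter). The remaining step is a 1.1-fold lower number from compound 1 to compound 2 (0.05 log units; within the scatter). Methanesulfonamido attaches through nitrogen, as do the groups of compound 1 and compound 2, so a large step to a lower number is expected.

The expected change is a 17-fold lower number from compound 3 to compound 4 (1.24 log units; beyond the scatter). For compound 4, the estimated value is 25000 nM, with an expected range of 7000 nM to 90000 nM.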

Compound 4, half-maximal effective concentration: 18000 nM
Compound 4: middle estimate off by 1.4-fold (0.14 log units), on the high side, and the stated range covers the measured number.
By their numbers in this assay, from the lowest: compounds 2, 1 and 4 (each within the scatter of the next); then compound 3.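

In this assay, methanesulfonamido in place of carbamoyl, para to a hydroxy group, gives a 24-fold lower number from compound 3 to compound 4 (1.38 log units; beyond the scatter), showing that a sulfonyl on the nitrogen can stand in for propanoyl, with a 1.1-fold higher number from compound 2 to compound 4 (0.05 log units; within the scatter). Against dimethylamino there is no change at the digits printed from compound 1 to compound 4 (within the scatter), so the three groups attached through nitrogen fall together, and carbamoyl alone stands apart. Nothing available explains this separation. Going by these compounds, whether an amine or a carboxylic acid at this place would fall with the nitrogen-attached groups or with carbamoyl stays open, as does the effect of a longer chain on the sulfonyl.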